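Thioguanosine series: from methylpyridylmethyl to nitrobenzyl on sulfur

This account rests on a few compounds, and the source may have more. Where it says the series, first, only, none or still open, it means among the compounds named here.

In an assay on isolated protein for binding affinity to Equilibrative nucleoside transporter 1 (Homo sapiens) (on this read-out lower numbers stand for stronger inhibition and higher numbers for weaker inhibition), the shared core carries different groups on sulfur. Compound 1 `Nc1nc(SI)c2ncn([C@@H]3O[C@H](CO)[C@@H](O)[C@H]3O)c2n1` gives 81300 nM, compound 2 `CC(C)Sc1nc(N)nc2c1ncn2[C@@H]1O[C@H](CO)[C@@H](O)[C@H]1O` gives 191000 nM, and compound 3 `Cc1cccc(CSc2nc(N)nc3c2ncn3[C@@H]2O[C@H](CO)[C@@H](O)[C@H]2O)n1` gives 11500000 nM, the highest number of the three. The steps are a 2.3-fold higher number from compound 1 to compound 2 (0.37 log units; beyond the scatter), a 140-fold higher number from compound 1 to compound 3 (2.15 log units; beyond the scatter) and a 60-fold higher number from compound 2 to compound 3 (1.78 log units; beyond the scatter), so compound 3 sits far above both smaller groups on sulfur. Compound 4 `Nc1nc(SCc2ccccc2[N+](=O)[O-])c2ncn([C@@H]3O[C@H](CO)[C@@H](O)[C@H]3O)c2n1` differs from compound 3 by 2-nitrophenyl in place of 6-methylpyridin-2-yl on a saturated chain carbon bound to a sulfur. Among the measured compounds shown here, none of the measured steps swaps one aromatic ring for another; the two large steps only show that the aryl-methyl group on sulfur in compound 3 gives a much higher number than iodo or isopropyl, and how a nitrophenyl ring would compare with the methylpyridinyl ring is not covered by any step here. Compound 4 is therefore expected to change by a 38-fold lower number from compound 3 to compound 4 (1.58 log units; beyond the scatter) in this assay, with wide uncertainty. The estimate for compound 4 is 300000 nM, expected between 30000 nM and 3000000 nM.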

Compound 4, half-maximal inhibitory concentration: 4570 nM
Compound 4: the middle estimate sits 66-fold (1.82 log units) above what was measured; the whole stated range lies above it.
By their numbers in this assay, from the lowest: compound 4; then compound 1; then compound 2; then compound 3.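

In this assay, among the compounds shown here, keeping the saturated chain carbon on sulfur and exchanging only the ring gives a 2500-fold lower number from compound 3 to compound 4 (3.40 log units; beyond the scatter), the largest step in the set, so the identity of the ring matters far more at this position than the earlier compounds could show. Compound 3 had given the highest number of its set, yet the 2-nitrobenzyl group gives a 42-fold lower number from compound 2 to compound 4 (1.62 log units; beyond the scatter) and an 18-fold lower number from compound 1 to compound 4 (1.25 log units; beyond the scatter), so ring-bearing groups on sulfur fall on both sides of isopropyl and iodo. Nothing available here explains why the two rings differ so widely.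

The compounds shown do not separate the contribution of the nitro group from the loss of the ring nitrogen and methyl of compound 3. They also leave open how an unsubstituted benzyl or a 2-aminobenzyl group on sulfur would compare.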